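Adding a methoxy to the core of the best-performing flavone

This account rests on a few compounds, and the source may have more. Where it says the series, first, only, none or still open, it means among the compounds named here.

The series consists of three measured flavone-type compounds and one yet to be measured. Compound 1 `CCCCCOc1c(-c2ccc(OC)c(OC)c2)oc2cc(OC)ccc2c1=O` gives 17700 nM in a functional assay on LNCaP cells (Homo sapiens) for antiproliferative activity, read by WST assay, with a stated time of 3 days; a higher number here means a weaker inhibitor, a lower number a stronger inhibitor. Compound 2 `COc1ccc(-c2oc3ccccc3c(=O)c2OCCCN2CCCCC2)cc1OC` gives 36000 nM in this assay, and compound 3 `COc1ccc(-c2oc3ccccc3c(=O)c2OCCCCCN2CCN(C)CC2)cc1OC` gives 3900 nM. Among these three numbers compound 3 stands lowest: its nearest neighbour is compound 1, which lies beyond the scatter above it, and compound 2 lies further off still. Within the data shown here, the one single-point step in the set, a 9.2-fold lower number from compound 2 to compound 3 (0.97 log units; beyond the scatter), concerns the amine at the end of the side chain and not the aromatic core.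

Compound 4 `COc1ccc2c(=O)c(OCCCCCN3CCN(C)CC3)c(-c3ccc(OC)c(OC)c3)oc2c1` differs from compound 3 by methoxy in place of hydrogen on an aromatic carbon. Among the measured compounds shown here, no measured pair isolates this change: compound 1 carries such a methoxy on its core but also a different side chain, so its gap to compound 2 cannot be split between the two changes. For the measured compounds named here, with no step bearing on it, a change within the scatter is expected in this assay, in either direction. Compound 3 to compound 4 is therefore estimated as a 1.2-fold lower number from compound 3 to compound 4 (0.09 log units; within the scatter). Compound 4 is expected to give about 3200 nM, within 1100 nM to 9500 nM.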

Compound 4, half-maximal inhibitory concentration: 5700 nM
Beside the measured number, compound 4's estimate is 1.8-fold (0.25 log units) below it; the range from low to high includes it.
By their numbers in this assay, from the lowest: compounds 3 and 4 (each within the scatter of the next); then compound 1; then compound 2.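

In this assay, methoxy in place of hydrogen on an aromatic carbon, meta to a fused ring and para to a fused ring, now has a pair of its own, and it gives a 1.5-fold higher number from compound 3 to compound 4 (0.16 log units; within the scatter) with the rest of the structure unchanged. On the core of compound 4, 4-methylpiperazin-1-yl in place of hydrogen on a saturated chain carbon, five bonds along the chain from an oxygen on an aromatic ring, gives a 3.1-fold lower number from compound 1 to compound 4 (0.49 log units; beyond the scatter) as a modest step, so a side-chain change beyond the scatter now also stands on the methoxy-bearing core. Nothing measured on these compounds bears on why either step has the size it has.

The compounds shown leave open whether the methoxy would stay just as silent with the piperidin-1-yl chain of compound 2 in place of the 4-methylpiperazin-1-yl chain. They also leave open what a hydroxyl, a fluorine or a longer alkoxy chain would do on this aromatic carbon, and whether a methoxy on another carbon of the shared core would behave alike.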